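This account rests on a few compounds, and the source may have more. Where it says the series, first, only, none or still open, it means among the compounds named here.

Within the data shown here, compound 1 `C=C1C[C@]23C[C@@]1(O)CC[C@H]2c1cc(Br)c(O)c(C)c1[C@@H]3Cn1cc(-c2ccc(F)cc2)nn1` is the only compound of the pair with a number in a functional assay on HL-60 cells (Homo sapiens) for cytotoxicity, read by MTT assay, with a stated time of 4 days (a higher number here means a weaker inhibitor, a lower number a stronger inhibitor), where compound 1 gives 6600 nM. Compound 2 `C=C1C[C@]23C[C@@]1(O)CC[C@H]2c1ccc(O)c(C)c1[C@@H]3Cn1cc(-c2ccc(F)cc2)nn1` reaches only the limit of this assay, at > 20000 nM. The step of an at least 3.0-fold higher number from compound 1 to compound 2 (0.48 log units; beyond the scatter) concerns the bromo on the aromatic ring, as set out in the limit of > 20000 nM in this assay, at which 1 of the 2 values shown sits. Compound 3 `C=C1C[C@]23C[C@@]1(O)CC[C@H]2c1cc(Br)c(O)c(C)c1[C@@H]3Cn1cc(-c2ccc(C)cc2)nn1` differs from compound 1 at another place: methyl in place of fluoro on an aromatic carbon. Among the measured compounds shown here, no measured step touches this position, so nothing beyond the scatter is expected in this assay in either direction. The step of no change at the digits printed from compound 1 to compound 3 (within the scatter) is therefore estimated as flat. Compound 3 is expected at 6600 nM, within 2500 nM to 18000 nM.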

Compound 3, half-maximal inhibitory concentration: > 20000 nM
Compound 3: only a limit was reported; the forecaster's own chance of this, stated with the estimate: 15%; middle value at least 3.0-fold (0.48 log units) away from the limit.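

Among these compounds, the change from 4-fluorophenyl to 4-methylphenyl gives an at least 3.0-fold higher number from compound 1 to compound 3 (0.48 log units; beyond the scatter), so this position, which no earlier step touched, also bears on the reading in this assay. Compound 3 gives > 20000 nM, which is a limit and not a number. Compound 1 remains the only compound of the three with a number, and both single changes away from it end at the limit: the limit of > 20000 nM in this assay, at which 2 of the 3 values shown sit.

As far as these compounds go, how far compound 2 and compound 3 lie past that limit stays unknown, so their steps cannot be ranked against each other. From the compounds shown here alone, whether chloro, methoxy or an amine at this position would give a lower number than compound 1 remains open.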